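A New Aryl Group on the Aromatic Nitrogen

The compounds below may be only part of what the source reports. "The series", "measured", "known", "first", "only" and "open" are said of these compounds alone.

Compound 1 `Cc1cc(=O)n(-c2ccccc2C(F)(F)F)nc1C(=O)Nc1ccc(Oc2ncnc3ccsc23)c(F)c1`: 4680 nM in a functional assay on A549 cells (Homo sapiens) for cytotoxicity, read by MTT assay, with a stated time of 72 h; on this read-out lower numbers stand for stronger inhibition and higher numbers for weaker inhibition
Compound 2 `Cc1cc(=O)n(-c2ccccc2C(F)(F)F)nc1C(=O)Nc1ccc(Oc2ncnc3sccc23)cc1`: 19900 nM
Compound 3 `Cc1cc(=O)n(-c2ccccc2C(F)(F)F)nc1C(=O)Nc1ccc(Oc2ncnc3sccc23)c(F)c1`: 16300 nM

Among these three numbers from this assay, compound 3 holds the second highest; compound 2 stands within the scatter of it, while compound 1 lies further off, as a 3.5-fold higher number from compound 1 to compound 3 (0.54 log units; beyond the scatter) shows. Compound 4 `Cc1cc(=O)n(-c2ccc(F)cc2)nc1C(=O)Nc1ccc(Oc2ncnc3sccc23)c(F)c1` keeps the core of compound 3 and differs only in the group on the aromatic nitrogen: 4-fluorophenyl in place of 2-(trifluoromethyl)phenyl on an aromatic nitrogen. Neither measured step touches that position: a 3.5-fold higher number from compound 1 to compound 3 (0.54 log units; beyond the scatter) concerns the group on the oxygen, and a 1.2-fold lower number from compound 2 to compound 3 (0.09 log units; within the scatter) concerns a fluoro in place of hydrogen on an aromatic carbon. There is therefore no basis here for expecting a change beyond the scatter in this assay in either direction, only a wide uncertainty. Compound 4 is accordingly expected to give about 15000 nM, between 4000 nM and 50000 nM. The expected step is a 1.1-fold lower number from compound 3 to compound 4 (0.04 log units; within the scatter).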

Compound 4, half-maximal inhibitory concentration: 2620 nM
The estimate for compound 4 lay 5.7-fold (0.76 log units) above the measured number; the measured number lies below the stated range.
By their numbers in this assay, from the lowest: compounds 4 and 1 (each within the scatter of the next); then compounds 3 and 2 (each within the scatter of the next).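

This first look at the group on the aromatic nitrogen shows that this position can move the number in this assay: 4-fluorophenyl in place of 2-(trifluoromethyl)phenyl gives a 6.2-fold lower number from compound 3 to compound 4 (0.79 log units; beyond the scatter). The swap changes both the group on the ring and the heavy-atom count, so this single step cannot separate the two differences. No measurement shown here explains the step. On these data alone, whether plain phenyl or a ring carrying a methoxy group would give a similar number remains open. So does whether 4-fluorophenyl would lower the number on the core of compound 1.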